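This account rests on a few compounds, and the source may have more. Where it says the series, first, only, none or still open, it means among the compounds named here.

Among the compounds with values here, compound 1 `CCCN(CCC)S(=O)(=O)NC(=O)Nc1c(C(C)C)cccc1C(C)C` is the only member of the series with a numerical result so far: in an assay on liver for inhibition of sterol O-acyltransferase 1 (Rattus norvegicus), using microsomes (a lower number here means a stronger inhibitor, a higher number a weaker inhibitor), compound 1 gives 1100 nM. Compound 2 `CCCCN(CCCC)S(=O)(=O)N(C)C(=O)Nc1c(C(C)C)cccc1C(C)C` has no number in this assay; for compound 2 the result is a limit, > 5000 nM. That is the limit of > 5000 nM in this assay, at which 1 of the 2 values shown sits, and it allows no comparison of size with compound 1.

Compound 3 `CCCCCCC(C)OS(=O)(=O)NC(=O)Nc1c(C(C)C)cccc1C(C)C` differs from compound 1 in one place: (1-methylheptyl)oxy in place of dipropylamino on a sulfonyl sulfur. Within the data shown here, no measured pair in the set shows a change at the sulfonyl sulfur, so nothing here calibrates the size of this step. The expectation for the move from compound 1 to compound 3 is a modest weakening in this assay, a 1.6-fold higher number from compound 1 to compound 3 (0.21 log units; within the scatter), with a real chance that the change is lost in the scatter. The estimate for compound 3 in this assay is 1800 nM, expected to fall between 500 nM and 6000 nM.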

Compound 3, half-maximal inhibitory concentration: 35000 nM
For compound 3 the middle estimate is 19-fold (1.29 log units) below the measured one, and the stated range ends below it.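

The sulfonyl sulfur proves to be a place where the substituent matters in this assay: (1-methylheptyl)oxy in place of dipropylamino gives a 32-fold higher number from compound 1 to compound 3 (1.50 log units; beyond the scatter). Within the data shown here, this is the first readable step at this position, and it shows that, on the core of compound 1, dipropylamino cannot be exchanged for this alkoxy chain without a large weakening. Nothing in the data shown accounts for the size of this step.

Among these compounds, the single step changes the linking atom and the chain together, so it remains open which of the two carries the effect. A propoxy group, or a (1-methylheptyl)amino group on the same sulfur, would separate the two, and a ring amine such as piperidine would test how far the nitrogen substituents can vary.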